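A few compounds are considered here, and "the series" means these few. Any claim that something is new, unique, unknown or untested is made for them only; others in the source may bear on it.

Measured so far:
compound 1 `C#Cc1cncc(C#Cc2ccc3ncn(-c4ccnc(N)n4)c3c2)c1` — 63100 nM
compound 2 `C=Cc1ccc(C#Cc2ccc3ncn(-c4ccnc(N)n4)c3c2)cn1` — 79400 nM

Compound 2 stands with the higher of the two numbers in an assay on Sf9 cells for inhibition of mitogen-activated protein kinase kinase kinase 14 variant S549D (Homo sapiens), with a stated time of 30 min, in the presence of a further agent that is not named here; a higher number here means a weaker inhibitor, a lower number a stronger inhibitor; its nearest neighbour is compound 1, and the step of a 1.3-fold higher number from compound 1 to compound 2 (0.10 log units; within the scatter) lies within the scatter, so the two cannot be ordered.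

Compound 3 `C#Cc1ncc(C#Cc2ccc3ncn(-c4ccnc(N)n4)c3c2)cn1` is not yet measured. It differs from compound 2 in one place: a group of 8 heavy atoms (6 carbon, 2 nitrogen; one six-membered aromatic ring with 2 hetero atoms) in place of a group of 8 heavy atoms (7 carbon, 1 nitrogen; one six-membered aromatic ring with 1 hetero atom), on a triple-bonded carbon. For the measured compounds named here, the only measured step that bears on this, a 1.3-fold higher number from compound 1 to compound 2 (0.10 log units; within the scatter), swapped one aromatic ring with 1 hetero atom, carrying a triple bond, for one carrying a double bond, and it stayed within the scatter. Going by the values given here, the change to compound 3 returns a triple bond outside aromatic rings and adds a second ring nitrogen; no measured step covers that second change. On this basis no step beyond the scatter is expected in this assay, in either direction.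

Compound 3 is therefore expected to give 70000 nM in this assay, within 30000 nM to 160000 nM, which corresponds to an expected step of a 1.1-fold lower number from compound 2 to compound 3 (0.05 log units; within the scatter).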

Compound 3, half-maximal inhibitory concentration: 79400 nM
Compound 3: middle estimate off by 1.1-fold (0.05 log units), on the low side; low and high end bracket the measured number.
By their numbers in this assay, from the lowest: compounds 1, 2 and 3 (each within the scatter of the next).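

In this assay, for the compounds shown here, the ring with 2 hetero atoms and a triple bond outside it gives no change at the digits printed from compound 2 to compound 3 (within the scatter) and also a 1.3-fold higher number from compound 1 to compound 3 (0.10 log units; within the scatter), so a second ring nitrogen, absent from the earlier compounds, does not separate compound 3 from either of them. Across the three compounds on this triple-bonded carbon, neither the ring hetero atom count nor the double or triple bond outside the ring moves the number beyond the scatter, and all three stay close together at a high level. Nothing available explains this flat result.

Still open, from the compounds shown here alone, is whether any group on this triple-bonded carbon can produce a step beyond the scatter, for example a ring carrying an amine or a carboxylic acid, or a saturated alkyl chain in place of the ring. Also open, going by these compounds, is whether a change to the shared core would matter more than these ring swaps.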